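Methoxy on the anilide ring of a thiadiazole carboxamide

This account rests on a few compounds, and the source may have more. Where it says the series, first, only, none or still open, it means among the compounds named here.

Compound 1, `O=C(O)CCc1nnc(C(=O)Nc2cccc(-c3cccc(Cl)c3)c2)s1`: 1690 nM
Compound 2, `O=C(O)CCc1nnc(C(=O)Nc2cccc(-c3ccco3)c2)s1`: 1640 nM
Compound 3, `O=C(O)CCc1ccc(OCc2nnc(C(=O)Nc3ccccc3)s2)cc1`: 1060 nM

All three compounds were tested in a functional assay on CHO cells for agonist activity at Free fatty acid receptor 1 (Homo sapiens), read by calcium flux; on this read-out lower numbers stand for an effect already at smaller amounts and higher numbers for an effect only at larger amounts of compound. Compound 3 gives the lowest of the three numbers, but its gap to compound 2 and to compound 1 lies within the scatter, so the three cannot be ranked against one another. For the measured compounds named here, the one measured step, a 1.0-fold lower number from compound 1 to compound 2 (0.01 log units; within the scatter), concerns a change on the outer aromatic ring at the other end of the molecule and leaves the number essentially unchanged.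

Compound 4, `COc1ccc(NC(=O)c2nnc(COc3ccc(CCC(=O)O)cc3)s2)cc1`, has not yet been measured. It differs from compound 3 by methoxy in place of hydrogen on an aromatic carbon; cut one bond further out, the change reads phenyl to 4-methoxyphenyl, or anilino to (4-methoxyphenyl)amino. Going by the values given here, no measured step touches this ring, so nothing in the data points to a shift in either direction. The step of a 1.1-fold lower number from compound 3 to compound 4 (0.05 log units; within the scatter) is therefore expected to stay within the scatter. For compound 4 the estimate is 950 nM, with a range from 400 nM to 2500 nM.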

Compound 4, half-maximal effective concentration: > 10000 nM
Compound 4: a limit, no number; the forecaster's own chance of this, stated with the estimate: 5%; middle value at least 10-fold (1.02 log units) from the limit.
By their numbers in this assay, from the lowest: compounds 3, 2 and 1 (each within the scatter of the next). At a limit, above all of these: compound 4.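

In this assay, this carbon of the six-membered aromatic ring, para to a large group, turns out to be sensitive to change: methoxy, with its 2 heavy atoms, in place of hydrogen gives an at least 9.4-fold higher number from compound 3 to compound 4 (0.97 log units; beyond the scatter). For the compounds shown here, the one earlier step, a 1.0-fold lower number from compound 1 to compound 2 (0.01 log units; within the scatter), lay on a different ring and gave no hint of this. Compound 4 stands at a limit of the assay and not at a number, so the step gives only the smallest possible size of the change: the limit of > 10000 nM in this assay, at which 1 of the 4 values shown sits.

The compounds shown do not tell whether any group at this carbon has the same effect, or whether it is specific to methoxy. A fluorine atom, a methyl group or a hydroxyl group in the same place would help separate these two readings.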